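From difluoromethyl to chloro on the shared core

A few compounds are considered here, and "the series" means these few. Any claim that something is new, unique, unknown or untested is made for them only; others in the source may bear on it.

Measured so far in an ADME assay on microsomes from liver (Rattus norvegicus) for metabolic stability, read by LC-MS, using NADPH, with a stated time of 10 min, tested at 0.5 uM (a higher number here means that more of the compound is left, a lower number that less of the compound is left), for two compounds
- compound 1 `COC(=O)Nc1cc(-c2cc(Cl)c(OC[C@@](C)(N)CC(C)C)cn2)ccn1` gives (99%)
- compound 2 `CC(C)C[C@](C)(N)COc1cnc(-c2ccnc(Cl)c2)cc1C(F)F` gives (93%)

Compound 2 (93%) lies within the usual scatter of compound 1 (99%). Compound 3 `CC(C)C[C@](C)(N)COc1cnc(-c2ccnc(Cl)c2)cc1Cl` departs from compound 2 in one place (chloro in place of difluoromethyl on an aromatic carbon), with chloro in place of difluoromethyl on an aromatic carbon. Among the measured compounds shown here, no measured pair yet shows this change, so no step beyond the scatter is expected in this assay. The estimated step is small (a number 1 percentage points lower from compound 2 to compound 3 (within the scatter)). Compound 3 is expected at 92%, within an estimated range from 82% to 100%.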

Compound 3, percent of the compound remaining: 98%
Compound 3: middle estimate off by 6 percentage points, on the low side; the range from low to high includes it.
By their numbers in this assay, from the lowest: compounds 2, 3 and 1 (each within the scatter of the next).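

In this assay, chloro in place of difluoromethyl on the aromatic carbon opposite the ring nitrogen gives a number 5 percentage points higher from compound 2 to compound 3 (within the scatter), so the two groups cannot be told apart at this position. Chloro in place of (methoxycarbonyl)amino on an aromatic carbon likewise gives a number 1 percentage points lower from compound 1 to compound 3 (within the scatter), and this change does not separate its two compounds either. Nothing measured here bears on the reason for these results.

All three compounds keep most of their material, so the result does not show how far this position can be changed. From the compounds shown here alone, it remains open whether a carboxylic acid, an amine or a longer chain on this aromatic carbon would leave less of the compound in this assay.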